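Working notes: from compound 3 to compound 4

This account rests on a few compounds, and the source may have more. Where it says the series, first, only, none or still open, it means among the compounds named here.

Measured so far in an assay for displacement of a labelled ligand from metabotropic glutamate receptor 5 (Rattus norvegicus); a lower number here means a stronger inhibitor, a higher number a weaker inhibitor: compound 1 `C(#Cc1ccccn1)C1=CC(Nc2cccnc2)CCC1` gives 7.3 nM; compound 2 `Cc1cccc(S(=O)(=O)N2CC=C(C#Cc3ccccn3)CC2)c1` gives 13 nM; compound 3 `Cc1ccc(S(=O)(=O)N2CC=C(C#Cc3ccccn3)CC2)cc1` gives 12 nM.

Compound 3 holds the second highest of the three numbers. Its nearest neighbour is compound 2, and the step of a 1.1-fold lower number from compound 2 to compound 3 (0.03 log units; within the scatter) stays within the scatter. The furthest number is that of compound 1, whose value sits below that of compound 3, yet the gap between the two also lies within the scatter, so the three numbers cannot be ordered.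

Compound 4 `O=S(=O)(c1ccc(Br)cc1)N1CC=C(C#Cc2ccccn2)CC1` has not yet been measured. Against compound 3 the change is bromo in place of methyl on an aromatic carbon, on an aromatic carbon of a six-membered aromatic ring of carbon only, para to a large group. Going by the values given here, the only measured step on that ring moves the methyl from one carbon to another and changes nothing beyond the scatter; no measured pair swaps a methyl for a bromo, so the expectation rests on that single step alone. The step of a 1.2-fold lower number from compound 3 to compound 4 (0.08 log units; within the scatter) is therefore expected to stay within the scatter. Compound 4 is estimated at 10 nM, with a range from 4 nM to 30 nM.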

Compound 4, inhibition constant: 3.1 nM
Compound 4: the middle estimate sits 3.2-fold (0.51 log units) above what was measured; measured number outside the range, below it.
By their numbers in this assay, from the lowest: compound 4; then compounds 1, 3 and 2 (each within the scatter of the next).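

In this assay, going by these compounds alone, bromo in place of methyl on this aromatic carbon, para to a large group, gives a 3.9-fold lower number from compound 3 to compound 4 (0.59 log units; beyond the scatter) and is the first change on this ring to pass the scatter, where moving the methyl in a 1.1-fold lower number from compound 2 to compound 3 (0.03 log units; within the scatter) did not. The change from 3-methylphenyl to 4-bromophenyl likewise gives a 4.2-fold lower number from compound 2 to compound 4 (0.62 log units; beyond the scatter) so compound 4 stands apart from both methylphenyl compounds. Nothing available here accounts for this difference.

The compounds shown leave open whether the lower number belongs to bromo alone or extends to chloro, methoxy or a nitrile on this carbon. Also open, as far as these compounds go, is whether bromo on another carbon of the ring keeps it, and whether an amide in place of the sulfonyl link would.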